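Nitrophenyl rearrangement in the di-tert-butyl glutamate series

The source may hold more compounds than are shown below. What is called first, only, known or untested is meant among the compounds shown, and "the series" means these compounds.

Measured so far:
compound 1 `COC(=O)c1ccc(CN(CCCc2c(N)nc(N)nc2O)c2cc(F)cc(F)c2[N+](=O)[O-])cc1`, > 100000 nM
compound 2 `CC(C)(C)OC(=O)CCC(Nc1ccc(CN(CCCc2c(N)nc(N)nc2O)c2cc(F)cc(F)c2[N+](=O)[O-])cc1)C(=O)OC(C)(C)C`, 7700 nM
compound 3 `COC(=O)c1ccc(CN(CCCc2c(N)nc(N)nc2O)c2cc(F)c([N+](=O)[O-])cc2[N+](=O)[O-])cc1`, 3500 nM

The read-out throughout is a functional assay on CCRF-CEM cells (Homo sapiens) for cytotoxicity, in the presence of a further agent that is not named here; on this read-out lower numbers stand for stronger inhibition and higher numbers for weaker inhibition. Compound 1 returns only a limit of the assay, > 100000 nM, and so yields no number; this is the case noted as the limit of > 100000 nM in this assay, at which 1 of the 3 values shown sits. Among the two compounds with a number, compound 2 stands at the higher one with 7700 nM. Compound 3 gives 3500 nM, the lower of the two, and the gap between compound 2 and compound 3 lies beyond the usual scatter. Among the measured compounds shown here, compound 2 and compound 3 differ in more than one place, so no single step between them is defined.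

The unmeasured compound 4 `CC(C)(C)OC(=O)CCC(Nc1ccc(CN(CCCc2c(N)nc(N)nc2O)c2ccc([N+](=O)[O-])c(F)c2F)cc1)C(=O)OC(C)(C)C` keeps every atom of compound 2 and changes only the aryl group on the amine nitrogen: 2,3-difluoro-4-nitrophenyl in place of 3,5-difluoro-2-nitrophenyl on an amine nitrogen. For the measured compounds named here, no measured step isolates such a rearrangement, so its direction is open. The expected step from compound 2 to compound 4 in this assay is a 2.2-fold lower number from compound 2 to compound 4 (0.34 log units; beyond the scatter), a small improvement at most, not confidently beyond the scatter. Compound 4 is accordingly estimated at 3500 nM, with a range from 900 nM to 14000 nM.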

Compound 4, half-maximal inhibitory concentration: 20000 nM
Beside the measured number, compound 4's estimate is 5.7-fold (0.76 log units) below it, outside the stated range (above it).
By their numbers in this assay, from the lowest: compound 3; then compound 2; then compound 4. At a limit, above all of these: compound 1.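

In this assay, among the compounds shown here, placing 2,3-difluoro-4-nitrophenyl in place of 3,5-difluoro-2-nitrophenyl on an amine nitrogen gives a 2.6-fold higher number from compound 2 to compound 4 (0.41 log units; beyond the scatter), a modest step and the only single-place comparison available. The leaving and entering groups have the same heavy atoms, ring type and counted hydrogen-bond features, so the result shows that rearranging the same nitro and fluorine substituents on this aryl group is enough to move the read-out, here in the unfavourable direction. Nothing measured here bears on the cause of this step.

Going by these compounds, whether the same rearrangement moves the read-out in the same direction and by a similar size on other parts of the molecule remains open, including the methyl benzoate scaffold of compound 1 and compound 3. Also open, on these data alone, is how the 2,3-difluoro-4-nitrophenyl group behaves when the two tert-butyl esters are replaced by free carboxylic acids, or when the saturated chain to the amine nitrogen is replaced by a longer chain.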